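Acylsemicarbazone aryl group: naphthol to resorcinol swap

The source may hold more compounds than are shown below. What is called first, only, known or untested is meant among the compounds shown, and "the series" means these compounds.

Measured compounds:
- Compound 1 `CN(C)CCn1cnnc1-c1cc(Oc2ccc(NC(=O)N/N=C/c3cc(C(C)(C)C)cc(C(C)(C)C)c3O)cc2F)ccn1`: 980 nM
- Compound 2 `CN(C)CCn1cnnc1-c1cc(Oc2ccc(NC(=O)N/N=C/c3c(O)ccc4ccccc34)cc2F)ccn1`: 880 nM
- Compound 3 `Cn1cnnc1-c1cc(Oc2ccc(NC(=O)N/N=C/c3ccccc3)cc2F)ccn1`: 7560 nM

The read-out is a functional assay on A549 cells (Homo sapiens) for cytotoxicity, read by MTT assay, with a stated time of 72 h; on this read-out higher numbers stand for weaker inhibition and lower numbers for stronger inhibition. Compound 2 gives the lowest number of the three, but compound 1 sits within the scatter of it, so no order between these two can be drawn. Compound 3, which carries neither the dimethylaminoethyl chain on the triazole nor a hydroxyl on the aryl ring of the hydrazone, gives a number beyond the scatter above compound 2; with two changes at once, the part played by each cannot be separated from these numbers.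

Compound 4 `CN(C)CCn1cnnc1-c1cc(Oc2ccc(NC(=O)N/N=C/c3ccc(O)cc3O)cc2F)ccn1` is not yet measured. It differs from compound 2 in one place: 2,4-dihydroxyphenyl in place of 2-hydroxynaphthalen-1-yl on a carbon with a double bond to nitrogen. The hydroxyl on the ring carbon next to the point of attachment is kept, the second fused ring is lost and a second hydroxyl enters. Going by the values given here, no measured pair shows this kind of change, so the direction is uncertain. The expected step of a 1.7-fold higher number from compound 2 to compound 4 (0.23 log units; within the scatter) is a small loss, at most just beyond the scatter. Compound 4 is estimated at 1500 nM, with a range from 600 nM to 4000 nM.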

Compound 4, half-maximal inhibitory concentration: 12700 nM
The estimate for compound 4 lay 8.5-fold (0.93 log units) below the measured number, and the stated range ends below it.
By their numbers in this assay, from the lowest: compounds 2 and 1 (each within the scatter of the next); then compounds 3 and 4 (each within the scatter of the next).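

In this assay, replacing 2-hydroxynaphthalen-1-yl with 2,4-dihydroxyphenyl on a carbon with a double bond to nitrogen gives a 14-fold higher number from compound 2 to compound 4 (1.16 log units; beyond the scatter). Going by these compounds alone, this is the first single-place comparison, and it shows that this position is not indifferent to the aryl group: with the rest of the molecule unchanged, this swap alone produces a large step, and keeping the hydroxyl common to both groups does not preserve the number seen for compound 2. Nothing available explains why the number moves this far.

The swap removes the second fused ring and adds a second hydroxyl in one step, so the pair of compound 2 and compound 4 cannot show whether the loss follows the missing ring, the added hydroxyl or both together. A hydroxyphenyl group with a single hydroxyl would address the ring on its own, and a methoxy group in place of the second hydroxyl would test that added group, leaving the contribution of each change open for now.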